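From Acetyl to Propanoyl: Expecting Compound 4

This account rests on a few compounds, and the source may have more. Where it says the series, first, only, none or still open, it means among the compounds named here.

In a functional assay on the whole organism (strain ICR) for inhibition, with Mus musculus as the target, with stated times of 7 days and 3 h, at a dose of 10 umol/kg by the intraperitoneal route (on this read-out lower numbers stand for less inhibition and higher numbers for more inhibition at the one dose given (going by the name of the read-out)), compound 1 `CC(=O)N1CCC(c2ccc(-c3cc(C(=O)O)cc4cc(-c5ccc(C(F)(F)F)cc5)ccc34)cc2)CC1` gives 92.4%, the highest of the three measured numbers. Compound 2 `O=C(O)c1cc(O)c2ccc(-c3ccc(C(F)(F)F)cc3)cc2c1` gives 35.2% and compound 3 `O=C(O)c1cc(-c2ccc(C3CCNCC3)cc2)cc(-n2cc(-c3ccc(C(F)(F)F)cc3)nn2)c1` gives 31.9%, both far lower than compound 1 and beyond the scatter. Compound 4 `CCC(=O)N1CCC(c2ccc(-c3cc(C(=O)O)cc4cc(-c5ccc(C(F)(F)F)cc5)ccc34)cc2)CC1` has not yet been measured. It differs from compound 1 in one place: methyl in place of hydrogen on a saturated chain carbon bound to a carbonyl carbon so that acetyl becomes propanoyl. Going by the values given here, no pair of measured compounds differs by a change this small, so nothing measured here shows how such a step behaves. Adding one carbon to the chain is expected to move the read-out only a little, most likely within the scatter. The expected step is a number 4.4 percentage points lower from compound 1 to compound 4 (within the scatter). Compound 4 is therefore estimated at 88%, within a range from 70% to 97%.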

Compound 4, a percentage reported as inhibition, in the whole organism at one dose (the size of the read-out at that dose, not a potency): 55.7%
The estimate for compound 4 lay 32.3 percentage points above the measured number; measured number below the stated range.
By their numbers in this assay, from the lowest: compounds 3 and 2 (each within the scatter of the next); then compound 4; then compound 1.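

In this assay, the change from acetyl to propanoyl brings a number 36.7 percentage points lower from compound 1 to compound 4 (beyond the scatter). This is the first one-place comparison among these compounds, and it shows that a single methyl at this position, on a saturated chain carbon bound to a carbonyl carbon, can shift the read-out well beyond the scatter. Nothing available explains the size of this step.

From the compounds shown here alone, this single step shows no trend, so it remains open whether butanoyl, a longer chain, would give a lower number than propanoyl. Also open, going by these compounds, is how formyl in place of acetyl would read.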